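Replacing the aryl group of compound 2

The source may hold more compounds than are shown below. What is called first, only, known or untested is meant among the compounds shown, and "the series" means these compounds.

In a functional assay on A-431 cells (Homo sapiens) for antiproliferative activity, read by CCK-8 assay, with a stated time of 72 h (on this read-out higher numbers stand for weaker inhibition and lower numbers for stronger inhibition), compound 1 (`C#Cc1cccc(Nc2ncnc3cc(OCCOC(=O)c4ccccc4OC(C)=O)c(OCCOC)cc23)c1`) gives 1800 nM and compound 2 (`C#Cc1cccc(Nc2ncnc3cc(OCCOC(=O)C(C)c4ccc(CC(C)C)cc4)c(OCCOC)cc23)c1`) gives 2200 nM, so the two stand level within the scatter. Compound 3 (`C#Cc1cccc(Nc2ncnc3cc(OCCOC(=O)C(C)c4ccc5cc(OC)ccc5c4)c(OCCOC)cc23)c1`) carries 6-methoxynaphthalen-2-yl in place of 4-isobutylphenyl on a saturated chain carbon bound to a carbonyl carbon and a saturated chain carbon. Among the compounds with values here, the only measured step, a 1.2-fold higher number from compound 1 to compound 2 (0.09 log units; within the scatter), also exchanged the group beyond the carbonyl and stayed within the scatter. On that single step, the expected change a 1.1-fold lower number from compound 2 to compound 3 (0.04 log units; within the scatter) is none beyond the scatter, with no direction favoured. The estimate for compound 3 is 2000 nM, with an expected range from 800 nM to 5000 nM.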

Compound 3, half-maximal inhibitory concentration: 3200 nM
Compound 3: middle estimate off by 1.6-fold (0.20 log units), on the low side; the measured number falls inside the stated range.
By their numbers in this assay, from the lowest: compounds 1, 2 and 3 (each within the scatter of the next).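

In this assay, within the data shown here, 6-methoxynaphthalen-2-yl in place of 4-isobutylphenyl gives a 1.5-fold higher number from compound 2 to compound 3 (0.16 log units; within the scatter), the first step in which the carbonyl and the saturated chain carbon stay and only the aryl group changes. At this place, then, a group with 2 six-membered aromatic rings and one hydrogen-bond acceptor stands level with one holding a single ring and none. Nothing given here bears on why the two stand level. The compounds shown leave open whether an amine or a carboxylic acid on the aryl group, or a longer chain at this carbon, would move the number beyond the scatter.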